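This account rests on a few compounds, and the source may have more. Where it says the series, first, only, none or still open, it means among the compounds named here.

Working notes on the series. Compound 1 `CN(C)c1ccc(/C=C/C=C/C(=O)c2ccccc2)cc1` is the parent of the set. In an ADME assay on RAW264.7 cells (Mus musculus) for cytotoxicity, read by MTT assay (a lower number here means a stronger inhibitor, a higher number a weaker inhibitor), compound 1 gives a limit of the assay, > 100000 nM. Compound 2 `CN(C)c1ccc(/C=C/C=C/C(=O)c2ccc(F)cc2)cc1` carries fluoro in place of hydrogen on an aromatic carbon; in this assay compound 2 also gives a limit, > 100000 nM. For the measured compounds named here, the single step on record, a step that the two limits leave unreadable from compound 1 to compound 2, is of unreadable size, because both ends sit at the limit of > 100000 nM in this assay, at which 2 of the 3 values shown sit. Compound 3 `CN(C)c1ccc(/C=C/C=C/C(=O)c2cccs2)cc1` carries thiophen-2-yl on the carbonyl carbon; in this assay compound 3 has no result, "not determined" (no result reported). Where compound 3 stands on the numbers shown is thus open: there is no number for it, and the two other values in the set are limits rather than numbers. Compound 4 `CN(C)c1ccc(/C=C/C=C/C(=O)c2ccco2)cc1` differs from compound 3 by furan-2-yl in place of thiophen-2-yl on a carbonyl carbon. Going by the values given here, no measured step bears on this change, and the only step recorded is itself unreadable, so no direction or size can be expected from the data beyond the scatter. Compound 4 is expected in this assay at 100000 nM, within 40000 nM to 300000 nM, most probably reported again only as a limit.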

Compound 4, half-maximal inhibitory concentration: > 100000 nM
Compound 4: no number, only a limit; the forecaster's own chance of this, stated with the estimate: 85%; the middle value sits exactly at the limit.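

No step can be read from compound 1 or compound 2 to compound 4 in this assay, because all three compounds give only a limit: the limit of > 100000 nM in this assay, at which 3 of the 4 values shown sit.

The compounds shown leave open how the phenyl, 4-fluorophenyl and furan-2-yl groups differ in this assay, and where compound 3 stands.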